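The source may report more compounds than this note shows. Statements on the series, on what has been measured and on what is new or still open speak of the compounds shown alone.

Compound 1 `O=C1CSC(c2cccc(Cl)c2)N1CCN1CCCCC1` and compound 2 `O=C1CSC(c2ccccc2[N+](=O)[O-])N1CCN1CCCCC1` share a core and have both been tested in an ADME assay on Vero cells (Chlorocebus sabaeus) for cytotoxicity, read by neutral red uptake, tested at 49 ug/mL; a higher number here means a weaker effect of the compound at the concentration tested, a lower number a stronger effect. In this assay compound 1 gives 100%. In this assay compound 2 gives 100%, level with compound 1 at the digits reported, so the two agree within the scatter and neither stands apart from the other. Compound 3 `O=C1CSC(c2ccccc2Cl)N1CCN1CCCCC1` has not yet been measured. It differs from compound 2 in one place: chloro in place of nitro on an aromatic carbon. Within the data shown here, no pair of measured compounds differs in exactly one place, so there is no measured step to guide the size of this change. What the two measured values show is that a chloro on the aromatic ring in compound 1 and a nitro on the same ring in compound 2 both come with the same full reading at this concentration, and nothing in them points to a swing when chloro replaces nitro. The expected step is therefore none beyond the scatter: no change at the digits printed from compound 2 to compound 3 (within the scatter). Compound 3 is expected to give 100% in this assay, with a range from 88% to 100%.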

Compound 3, a percentage reported as activity, at one concentration (the size of the read-out at that concentration, not a potency): 100%
Compound 3: the middle estimate sits on the measured number at the digits printed, within the range that was stated.
By their numbers in this assay, from the lowest: compounds 1, 2 and 3 (each within the scatter of the next).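

Where the earlier compounds could only be set side by side across two changes at once, compound 3 gives the first single-place steps in this assay. Chloro in place of nitro on an aromatic carbon, ortho to a large group, gives no change at the digits printed from compound 2 to compound 3 (within the scatter), so at this position the reading at the tested concentration does not respond to this exchange of groups. With the chloro kept, 2-chlorophenyl in place of 3-chlorophenyl on a saturated ring carbon gives no change at the digits printed from compound 1 to compound 3 (within the scatter), which shows that shifting the chloro between these two ring positions leaves the reading equally unmoved. Nothing available explains why neither change registers in this read-out. The compounds shown leave open whether an amine or a carboxylic acid on the same aromatic carbon, or a longer chain in place of the chloro, would move the reading, and whether these same steps would stay flat at any concentration other than the single one tested here.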